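The source may hold more compounds than are shown below. What is called first, only, known or untested is meant among the compounds shown, and "the series" means these compounds.

For the measured compounds named here, in an ADME assay (liver) for metabolic stability, with Liver microsome (Homo sapiens) as the target, using microsomes and NADPH, with a stated time of 30 min, tested at 1 uM (a lower number here means slower removal, a higher number faster removal of the compound), compound 1 `COCC#Cc1cc(C(O)(C(F)(F)F)C(F)(F)F)cnc1N1CCN(S(=O)(=O)c2ccc(N)nc2)CC1` gives 15 mL.min-1.g-1 and compound 2 `Nc1ccc(S(=O)(=O)N2CCN(c3ncc(C(O)(C(F)(F)F)C(F)(F)F)cc3-c3ccncc3)CC2)cn1` gives 15 mL.min-1.g-1 on the same read-out, so compound 2 stands level with compound 1, its only measured neighbour. Compound 3 `Nc1ccc(S(=O)(=O)N2CCN(c3ncc(C(O)(C(F)(F)F)C(F)(F)F)cc3-c3cccnc3)CC2)cn1` is not yet measured. Its difference from compound 2 is pyridin-3-yl in place of pyridin-4-yl on an aromatic carbon with pyridin-3-yl in place of pyridin-4-yl on an aromatic carbon, ortho to a large group, and the two compounds have the same atoms, joined differently. Going by the values given here, only one measured step bears on this carbon, the exchange of 3-methoxyprop-1-yn-1-yl for pyridin-4-yl, which is no change at the digits printed from compound 1 to compound 2 (within the scatter) in intrinsic clearance. Among the compounds with values here, no measured pair compares pyridin-3-yl with pyridin-4-yl, so the evidence is indirect and thin. Two quite different groups on this carbon gave compound 2 15 mL.min-1.g-1 and compound 1 15 mL.min-1.g-1 in the same assay, so no shift in either direction beyond the scatter is expected for two isomeric pyridinyl groups. The expected step is no change at the digits printed from compound 2 to compound 3 (within the scatter) on this single precedent. Compound 3 is estimated at 15 mL.min-1.g-1 with an expected range of 8 mL.min-1.g-1 to 29 mL.min-1.g-1 in this read-out.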

Compound 3, intrinsic clearance in microsomes: 17 mL.min-1.g-1
Estimate against measurement, compound 3: 1.1-fold (0.05 log units) below, and the stated range covers the measured number.
By their numbers in this assay, from the lowest: compounds 1, 2 and 3 (each within the scatter of the next).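

In this assay, for the compounds shown here, pyridin-3-yl in place of pyridin-4-yl on the aromatic carbon ortho to a large group gives a 1.1-fold higher number from compound 2 to compound 3 (0.05 log units; within the scatter) and so provides the first direct comparison of two isomeric pyridinyl groups at this position: the placement of the ring nitrogen in this substituent leaves the read-out within the scatter. The exchange of 3-methoxyprop-1-yn-1-yl for pyridin-3-yl gives a 1.1-fold higher number from compound 1 to compound 3 (0.05 log units; within the scatter) and, together with the earlier exchange for pyridin-4-yl, makes three groups on this carbon that this assay does not separate, with none of the three compounds going against this. No accompanying evidence bears on the origin of this flat result.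

Going by these compounds, whether the same holds for pyridin-2-yl or for groups of a different kind on this carbon, such as an amine, a carboxylic acid or a longer chain, remains open. On these data alone, the 2,2,2-trifluoro-1-hydroxy-1-(trifluoromethyl)ethyl group is the same in all three compounds, so the response of intrinsic clearance to a change at that group also remains open.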